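A Methyl on the Phenol Oxygen, Tried Twice

The source may report more compounds than this note shows. Statements on the series, on what has been measured and on what is new or still open speak of the compounds shown alone.

Compound 1 `O=C(/C=C\Nc1ccc(O)cc1)c1cn(-c2ccccc2)nc1-c1ccccc1` and compound 3 `O=C(/C=C\Nc1ccc(O)cc1)c1cn(-c2ccccc2)nc1-c1ccc(Cl)cc1` share one core and differ only by chloro in place of hydrogen on an aromatic carbon. In an ADME assay on HaCaT cells (Homo sapiens) for antiproliferative activity, read by MTT assay, with a stated time of 48 h (a lower number here means a stronger inhibitor, a higher number a weaker inhibitor), compound 1 gives 44600 nM. Compound 3 gives 22600 nM in this assay, so a 2.0-fold lower number from compound 1 to compound 3 (0.30 log units; within the scatter). Compound 2 `COc1ccc(N/C=C\C(=O)c2cn(-c3ccccc3)nc2-c2ccccc2)cc1` carries the change methyl in place of hydrogen on an oxygen on an aromatic ring relative to compound 1. In this assay compound 2 reaches only a limit of the assay, > 50000 nM. Accordingly an at least 1.1-fold higher number from compound 1 to compound 2 (0.04 log units; that floor lies within the scatter), which rests on (the limit of > 50000 nM in this assay, at which 1 of the 3 values shown sits). Compound 4 `COc1ccc(N/C=C\C(=O)c2cn(-c3ccccc3)nc2-c2ccc(Cl)cc2)cc1` is not yet measured; it stands to compound 3 exactly as compound 2 stands to compound 1, through the same change, (methyl in place of hydrogen on an oxygen on an aromatic ring). The expectation for compound 4 rests on compound 3, which gives 22600 nM, and on the measured step of an at least 1.1-fold higher number from compound 1 to compound 2 (0.04 log units; that floor lies within the scatter). Compound 4 is therefore expected to show a 2.0-fold higher number from compound 3 to compound 4 (0.30 log units; within the scatter). Compound 4 is estimated at 45000 nM, with a likely range from 22000 nM to 90000 nM.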

Compound 4, half-maximal inhibitory concentration: 30800 nM
Beside the measured number, compound 4's estimate is 1.5-fold (0.16 log units) above it, and the stated range covers the measured number.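

In this assay, hydroxy to methoxy gives a 1.4-fold higher number from compound 3 to compound 4 (0.13 log units; within the scatter), and chloro in place of hydrogen on an aromatic carbon gives an at least 1.6-fold lower number from compound 2 to compound 4 (0.21 log units; that floor lies within the scatter). Compound 2 stands at a limit of the assay, > 50000 nM. The step on the core of compound 3 lies within the scatter, but the series does not show that the change keeps one size when carried from one core to the other: the same change on two cores in this assay, an at least 1.1-fold higher number (0.04 log units; that floor lies within the scatter) from compound 1 to compound 2 and a 1.4-fold higher number (0.13 log units; within the scatter) from compound 3 to compound 4; the limit leaves it open whether they differ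

The compounds shown leave open how a longer chain on this oxygen, such as ethoxy, or an amine in place of the hydroxy group would read in this assay. They also leave open how bromo or fluoro would compare with chloro on either core.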